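Ring-Constrained Acid Analogue of a Dichloropyridine Alkyne

This account rests on a few compounds, and the source may have more. Where it says the series, first, only, none or still open, it means among the compounds named here.

Compound 1 `O=C(O)CCc1ccc(C#Cc2ccnc(Cl)c2)cc1` gives 295 nM in an in vitro functional assay on 1321-N1 cells for agonist activity at Free fatty acid receptor 1 (Homo sapiens), read by fluorescence, spectrophotometry and calcium flux; a higher number here means that more compound is needed for the effect, a lower number that less compound is needed. Compound 2 `O=C(O)CCc1ccc(C#Cc2cc(Cl)nc(Cl)c2)cc1` gives 40.7 nM, the lowest of the two numbers. Within the data shown here, the single measured step, a 7.2-fold lower number from compound 1 to compound 2 (0.86 log units; beyond the scatter), concerns a chloro group and not the acid side chain. Compound 3 `O=C(O)C1CC1c1ccc(C#Cc2cc(Cl)nc(Cl)c2)cc1` differs from compound 2 by 2-carboxycyclopropyl in place of 2-carboxyethyl on an aromatic carbon, on an aromatic carbon of a six-membered aromatic ring of carbon only, para to a large group. Among the measured compounds shown here, no measured step bears on this change, so the expected step is one within the scatter: a 1.0-fold lower number from compound 2 to compound 3 (0.01 log units; within the scatter). Compound 3 is therefore estimated at 40 nM, within 10 nM to 160 nM.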

Compound 3, half-maximal effective concentration: 42.7 nM
Compound 3: middle estimate off by 1.1-fold (0.03 log units), on the low side, and the stated range covers the measured number.
By their numbers in this assay, from the lowest: compounds 2 and 3 (each within the scatter of the next); then compound 1.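

In this assay, 2-carboxycyclopropyl in place of 2-carboxyethyl on an aromatic carbon, para to a large group, gives a 1.0-fold higher number from compound 2 to compound 3 (0.02 log units; within the scatter), so at this position the three-membered ring is tolerated, with the two numbers within the scatter of each other. Among these compounds, the earlier step concerned only a chloro group, so this is the first reading on the acid side chain. Nothing available here bears on why the two side chains read alike. Left open is how a longer chain, or a tetrazole in place of the carboxylic acid, would read at this position, and whether the same exchange holds on the core of compound 1.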